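A Single Added Chain on Compound 1

The compounds below may be only part of what the source reports. "The series", "measured", "known", "first", "only" and "open" are said of these compounds alone.

Compound 1 `COc1cc(O)c(C(=O)/C=C/c2ccc(N3CCNCC3)cc2)c(OC)c1`: 67500 nM
Compound 2 `CCc1c(OC)cc(OC)c(C(=O)/C=C/c2cccc(N3CCNCC3)c2)c1O`: > 100000 nM (a limit, not a number)

Both compounds were tested in an ADME assay on MCF7-DOX cells (Homo sapiens) for cytotoxicity, read by MTT assay, with a stated time of 48 h; a higher number here means a weaker inhibitor, a lower number a stronger inhibitor. In this assay, among the measured compounds shown here, compound 1 gives 67500 nM, the only true number available. Compound 2 is reported only as the limit > 100000 nM. Compound 2 differs from compound 1 in more than one place, so the pair offers no clean single-change comparison.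

The next compound to be tested is compound 3 `COc1cc(OC)c(C(=O)/C=C/c2ccc(N3CCNCC3)cc2)c(O)c1CC=C(C)C`. It keeps the core of compound 1 and changes in one place: 3-methylbut-2-en-1-yl in place of hydrogen on an aromatic carbon. A 3-methylbut-2-en-1-yl group takes the place of hydrogen on an aromatic carbon.

For the measured compounds named here, no measured step shows what such a change does, so any forecast is tentative and rests mainly on compound 1 at 67500 nM. A modest move towards stronger inhibition seems the likeliest outcome, little beyond the usual scatter. The expected change is a 2.3-fold lower number from compound 1 to compound 3 (0.35 log units; beyond the scatter). For compound 3 the estimated value is 30000 nM, with an expected range from 8000 nM to 100000 nM.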

Compound 3, half-maximal inhibitory concentration: 57800 nM
Compound 3: the middle estimate sits 1.9-fold (0.28 log units) below what was measured; measured number inside the range.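

In this assay, placing a 3-methylbut-2-en-1-yl chain on this aromatic carbon, ortho to a hydroxy group and para to a methoxy group, gives a 1.2-fold lower number from compound 1 to compound 3 (0.07 log units; within the scatter), so compound 1 and compound 3 cannot be told apart. Among the compounds shown here, this is the first clean single-change step in the set, and it shows that this carbon can carry a chain of this kind without a shift in the read-out that rises above ordinary measurement noise. The read-outs also lie not far from the top of what the assay reports, where compound 2 stands as a limit and not as a true number: the limit of > 100000 nM in this assay, at which 1 of the 3 values shown sits.

As far as these compounds go, one step at one position says little about other groups there, so it remains open whether an amine, a carboxylic acid or a longer chain such as geranyl on the same carbon would move the number any more clearly. From the compounds shown here alone, it is also open whether this neutral result belongs to the 3-methylbut-2-en-1-yl chain alone or would hold for other chains on the core of compound 1.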